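Tolerability of Sulfonamides: From Compound 3 to Compound 4

The source may hold more compounds than are shown below. What is called first, only, known or untested is meant among the compounds shown, and "the series" means these compounds.

Measured so far in an ADME assay on HEK293 cells (Homo sapiens) for cytotoxicity, read by resazurin assay, with a stated time of 48 h; a higher number here means that more compound is tolerated, a lower number that less compound is tolerated:
Compound 1 `O=S(=O)(Nc1ccc2oc(-c3ccccc3)nc2c1)c1ccccc1Cl` gives 73000 nM.
Compound 2 `O=S(=O)(Nc1ccc2oc(-c3ccccc3)nc2c1)c1cccc(F)c1` gives 68000 nM.
Compound 3 `O=S(=O)(Nc1ccc2oc(-c3ccccc3)nc2c1)c1ccccc1F` gives 72000 nM.

Compound 3 stands second highest of the three numbers, with a 1.0-fold lower number from compound 1 to compound 3 (0.01 log units; within the scatter) and a 1.1-fold higher number from compound 2 to compound 3 (0.02 log units; within the scatter), so all three values sit within the scatter of one another. Compound 4 `CCc1ccc(S(=O)(=O)Nc2ccc3oc(-c4ccccc4)nc3c2)cc1` differs from compound 3 by 4-ethylphenyl in place of 2-fluorophenyl on a sulfonyl sulfur. Among the measured compounds shown here, the steps that bear on this are the earlier exchanges of the aryl group on the sulfonyl sulfur, a 1.1-fold lower number from compound 1 to compound 2 (0.03 log units; within the scatter) and a 1.1-fold higher number from compound 2 to compound 3 (0.02 log units; within the scatter), both within the scatter. Replacing a halogen-bearing ring with an ethyl-bearing ring is not directly covered, so the expectation rests on the flatness seen so far. In this assay compound 4 is expected to give 62000 nM, between 32000 nM and 120000 nM, an expected 1.2-fold lower number from compound 3 to compound 4 (0.06 log units; within the scatter).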

Compound 4, half-maximal cytotoxic concentration: 81000 nM
The estimate for compound 4 lay 1.3-fold (0.12 log units) below the measured number; measured number inside the range.
By their numbers in this assay, from the lowest: compounds 2, 3, 1 and 4 (each within the scatter of the next).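

Putting 4-ethylphenyl on the sulfonyl sulfur in place of a halogen-bearing ring leaves this assay flat: a 1.1-fold higher number from compound 3 to compound 4 (0.05 log units; within the scatter), a 1.2-fold higher number from compound 2 to compound 4 (0.08 log units; within the scatter) and a 1.1-fold higher number from compound 1 to compound 4 (0.05 log units; within the scatter). The flatness seen among the chloro and fluoro rings of compounds 1, 2 and 3 therefore also holds for compound 4, whose ring carries no halogen but an ethyl chain. No measurement at hand explains this tolerance.

As far as these compounds go, whether an amine or a carboxylic acid on this ring, or a chain longer than ethyl, would move the number remains open. So does the effect of any change to the shared core.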